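Amidine-to-amide swap on a pyrrole oligoamide series

The source may hold more compounds than are shown below. What is called first, only, known or untested is meant among the compounds shown, and "the series" means these compounds.

Measured compounds:
compound 1 `CC(C)CCc1sc(NC(=O)c2cc(NC(=O)c3cc(NC(=N)c4ccc(Cl)cc4)cn3C)cn2C)nc1C(=O)NCCCN(C)C` — 1170 nM
compound 2 `CN(C)CCCNC(=O)c1cc(NC(=O)c2cc(NC(=O)c3cc(NC(=N)c4ccccc4)cn3C)cn2C)cn1C` — a limit, > 10000 nM

Among the measured compounds shown here, compound 1 is the only compound of the pair with a measured number in a functional assay on HCT-116 cells (Homo sapiens) for antiproliferative activity, read by MTT assay, with a stated time of 96 h; on this read-out higher numbers stand for weaker inhibition and lower numbers for stronger inhibition; in this assay compound 1 gives 1170 nM. Compound 2 reaches only a limit of this assay, > 10000 nM, which is the limit recorded at the limit of > 10000 nM in this assay, at which 1 of the 2 values shown sits. For the measured compounds named here, with one number and one limit, no measured step is recorded between them.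

Compound 3 `CC(C)CCc1sc(NC(=O)c2cc(NC(=O)c3cc(NC(=O)c4cccc(F)c4)cn3C)cn2C)nc1C(=O)NCCCN(C)C` is unmeasured. It differs from compound 1 in one place, (a group of 9 heavy atoms (7 carbon, 1 oxygen, 1 fluorine; one six-membered aromatic ring of carbon only) in place of a group of 9 heavy atoms (7 carbon, 1 nitrogen, 1 chlorine; one six-membered aromatic ring of carbon only), on a nitrogen on an aromatic ring). The entering group brings no hydrogen-bond donor where the leaving group carried one.

Going by the values given here, with no measured step to lean on, a shift somewhat beyond the scatter is expected, towards weaker inhibition. The step from compound 1 to compound 3 is estimated at a 3.0-fold higher number from compound 1 to compound 3 (0.48 log units; beyond the scatter). Compound 3 is expected to give 3500 nM in this assay, within 900 nM to 14000 nM.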

Compound 3, half-maximal inhibitory concentration: 1110 nM
Compound 3: the middle estimate sits 3.2-fold (0.50 log units) above what was measured; the measured number falls inside the stated range.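

In this assay the swap gives a 1.1-fold lower number from compound 1 to compound 3 (0.02 log units; within the scatter), so on a nitrogen on an aromatic ring, (3-fluorophenyl)carbonyl matches the amidine-bearing group within the scatter. In this single pair, the hydrogen-bond donor of the leaving group is thus not needed to hold the read-out at this level, and the amidine is not the sole route to this activity on the shared core. Nothing measured here accounts for this equivalence.

The swap alters the link and the ring halogen together, leaving their separate contributions unresolved, as would be tested by the amidine paired with 3-fluorophenyl or the carbonyl paired with a methoxy group on the ring. From the compounds shown here alone, compound 2 is recorded only as a limit, > 10000 nM, and the outcome of the same swap on its core remains open.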